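A few compounds are considered here, and "the series" means these few. Any claim that something is new, unique, unknown or untested is made for them only; others in the source may bear on it.

Measured compounds:
- compound 1 `CC(C)(C)c1ccc(CNCCCNS(=O)(=O)c2cc(C(F)(F)F)cc(C(F)(F)F)c2)cc1`: 2900 nM
- compound 2 `COc1cccc(CNCCCNS(=O)(=O)c2cc(C(F)(F)F)cc(C(F)(F)F)c2)c1`: 1600 nM
- compound 3 `CN(CCCNS(=O)(=O)c1cc(C(F)(F)F)cc(C(F)(F)F)c1)Cc1ccccc1`: 28000 nM

In a functional assay on A2780 cells (Homo sapiens) for inhibition, read by MTT assay, with a stated time of 72 h (a lower number here means a stronger inhibitor of growth, a higher number a weaker inhibitor of growth), compound 3 gives the highest number of the three. Compound 1 gives 2900 nM and compound 2 gives 1600 nM, with the step of a 1.8-fold lower number from compound 1 to compound 2 (0.26 log units; within the scatter), so the two secondary amines are not separated beyond the scatter. The step of an 18-fold higher number from compound 2 to compound 3 (1.24 log units; beyond the scatter) is the one large movement in the set, and it combines two changes at once: a methyl enters on the amine nitrogen and the 3-methoxy leaves the benzyl ring.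

Compound 4 `O=S(=O)(NCCCNCc1ccccc1)c1cc(C(F)(F)F)cc(C(F)(F)F)c1` differs from compound 3 by hydrogen in place of methyl on an amine nitrogen. This reverts the amine part of the change seen in the step from compound 2 to compound 3 while keeping the plain benzyl. Most of the large step is attributed to the methyl on the amine nitrogen because a 1.8-fold lower number from compound 1 to compound 2 (0.26 log units; within the scatter) shows the ring substituent counts for little while an 18-fold higher number from compound 2 to compound 3 (1.24 log units; beyond the scatter) is the one large movement, and its removal is expected to bring compound 4 back toward compounds 1 and 2.

For compound 4 the expected value in this assay is 3000 nM, range 1000 nM to 9000 nM. The expected step is a 9.3-fold lower number from compound 3 to compound 4 (0.97 log units; beyond the scatter).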

Compound 4, concentration for 50% growth inhibition: 4900 nM
Compound 4: the middle estimate sits 1.6-fold (0.21 log units) below what was measured, and the stated range covers the measured number.
By their numbers in this assay, from the lowest: compounds 2, 1 and 4 (each within the scatter of the next, the first and the last beyond it); then compound 3.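

In this assay, hydrogen in place of methyl on the amine nitrogen gives a 5.7-fold lower number from compound 3 to compound 4 (0.76 log units; beyond the scatter) with the plain benzyl held constant, so the methyl change now stands alone rather than mixed with a ring change as in the earlier large step. The ring substituent is not silent, however: hydrogen in place of methoxy gives a 3.1-fold higher number from compound 2 to compound 4 (0.49 log units; beyond the scatter) and so carries a modest share of that large step, while hydrogen in place of tert-butyl gives a 1.7-fold higher number from compound 1 to compound 4 (0.23 log units; within the scatter) and stays unresolved. No measurement shown offers a reason for any of these steps.

On these data alone, how the methyl on the amine nitrogen behaves with the 3-methoxyphenyl group kept remains open. Also open, as far as these compounds go, is what an ethyl or acetyl group on that nitrogen, or a longer chain on the sulfonamide nitrogen, would do in this assay.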